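The compounds below may be only part of what the source reports. "The series", "measured", "known", "first", "only" and "open" are said of these compounds alone.

The measured compounds:

compound 1, `FC(F)(F)c1cc(NC[C@@H]2CCCCN2)c2cn[nH]c2c1`: 64%
compound 2, `CNC(=O)c1cccc(CNc2cc(C(F)(F)F)cc3[nH]ncc23)c1`: 71%

In an assay for inhibition of Tryptophan 2,3-dioxygenase (Homo sapiens), with stated times of 10 min and 60 min, tested at 10 uM (a higher number here means a stronger effect of the compound at the concentration tested, a lower number a weaker effect), compound 1 gives 64%, and compound 2 gives 71%. For the measured compounds named here, compound 2 has the higher of the two numbers, but its only neighbour is compound 1, whose number lies within the usual scatter of it, so the two compounds are not distinguished by this assay. Going by the values given here, no step between measured compounds that differ in one place is available, so the shared core of compound 2 has no mapped substituent effect.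

Compound 3, `FC(F)(F)c1cc(NCc2cccc(Br)c2)c2cn[nH]c2c1`, is the next compound. It differs from compound 2 in one place: bromo in place of methylcarbamoyl on an aromatic carbon. Among the compounds with values here, with no measured step of this kind on hand, the step is expected to be modest, with the chance of a small loss, a change not clearly beyond the scatter. Compound 3 is therefore estimated at 58%, between 32% and 82%. This estimate means a step of a number 13 percentage points lower from compound 2 to compound 3 (beyond the scatter) in this assay.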

Compound 3, a percentage reported as inhibition, at one concentration (the size of the read-out at that concentration, not a potency): 67%
For compound 3 the middle estimate is 9 percentage points below the measured one, within the range that was stated.
By their numbers in this assay, from the lowest: compounds 1, 3 and 2 (each within the scatter of the next).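

In this assay, for the compounds shown here, the first step at this aromatic carbon, bromo in place of methylcarbamoyl, gives a number 4 percentage points lower from compound 2 to compound 3 (within the scatter), so a single bromine atom with no hydrogen-bond donor or acceptor stands level with the larger amide group, and this assay does not separate the two. The change on the saturated chain carbon bound to the nitrogen, 3-bromophenyl in place of piperidin-2-yl, gives a number 3 percentage points higher from compound 1 to compound 3 (within the scatter), so this second, larger replacement also leaves the read-out at the concentration tested undistinguished. No supporting data bear on why either change leaves the compounds undistinguished. From the compounds shown here alone, it remains open whether a carboxylic acid or an amine on this aromatic carbon would move the number beyond the scatter. The same question stands for a longer chain in place of the 3-bromophenyl group.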